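Compound 4: methoxy to hydroxy on the leading compound

A few compounds are considered here, and "the series" means these few. Any claim that something is new, unique, unknown or untested is made for them only; others in the source may bear on it.

Among the measured compounds shown here, in a functional assay on HaCaT cells (Homo sapiens) for antiproliferative activity, read by sulforhodamine B assay, with a stated time of 3 days (on this read-out lower numbers stand for stronger inhibition and higher numbers for weaker inhibition), compound 3 `COC(=O)c1cc(CCc2cc(OC)ccc2O)ccc1O` gives 1100 nM, the lowest number so far. Compound 1 `COC(=O)c1cc(CCc2ccccc2OC)ccc1O` reads 20000 nM and compound 2 `COC(=O)c1cc(CCc2cccc(OC)c2)ccc1O` reads 37000 nM.

Compound 4 `COC(=O)c1cc(CCc2cc(O)ccc2O)ccc1O` differs from compound 3 by a single change, hydrogen in place of methyl on an oxygen on an aromatic ring, or methoxy to hydroxy: hydrogen in place of methyl on an oxygen on an aromatic ring.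

For the measured compounds named here, only one measured step bears on this change: a 34-fold lower number from compound 2 to compound 3 (1.53 log units; beyond the scatter), which is large and comes from hydroxy in place of hydrogen on an aromatic carbon. That step adds a hydroxy to the compound, whereas the new change replaces a methoxy with one, so it is only an indirect guide. Going by the values given here, no measured pair shows methoxy to hydroxy itself. A much smaller move towards a lower number in this assay is therefore expected, possibly not beyond the scatter.

The estimated change is a 1.8-fold lower number from compound 3 to compound 4 (0.26 log units; within the scatter). For compound 4 the expected value is 600 nM, with an estimated range of 150 nM to 2500 nM.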

Compound 4, half-maximal inhibitory concentration: 21000 nM
Compound 4: middle estimate off by 35-fold (1.54 log units), on the low side; measured number above the stated range.
By their numbers in this assay, from the lowest: compound 3; then compounds 1, 4 and 2 (each within the scatter of the next).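

Among the compounds shown here, the methyl on this oxygen on an aromatic ring counts for much in this assay: its replacement by hydrogen gives a 19-fold higher number from compound 3 to compound 4 (1.28 log units; beyond the scatter), a large loss that the earlier compounds could not reveal. Set beside a 34-fold lower number from compound 2 to compound 3 (1.53 log units; beyond the scatter), which concerns a hydroxy added on an aromatic carbon, this shows that a gain from one hydroxy does not carry over to a second one replacing the methoxy, so the two groups are not interchangeable here in compound 3. Nothing measured on these compounds accounts for the size of this step.

Still open, going by these compounds, is whether the methyl itself is the requirement or whether a longer chain on this oxygen, such as ethoxy, would hold the number of compound 3. Equally open, on these data alone, is how a non-oxygen group, such as chlorine or an amine, would read at this place.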